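Working notes on a three-compound series and a fourth

The source may report more compounds than this note shows. Statements on the series, on what has been measured and on what is new or still open speak of the compounds shown alone.

Measured so far in an assay on isolated protein for inhibition of RAC-alpha serine/threonine-protein kinase (Homo sapiens), read by mobility shift assay, tested at 30 uM; on this read-out higher numbers stand for more inhibition at the one concentration tested (going by the name of the read-out) and lower numbers for less inhibition:
compound 1 `Cc1cc2[nH]nc(N)c2c(=O)[nH]1`: -3%
compound 2 `Cc1cc2c(c(N)nn2C)c(=O)[nH]1`: 11%
compound 3 `Cn1nc(N)c2c(=O)[nH]c(-c3ccccc3)cc21`: 8%

Compound 2 holds the highest of the three numbers in this assay. Compound 3 sits within the scatter of it, so no order between the two is claimed; compound 1 sits further off, the step of a number 14 percentage points higher from compound 1 to compound 2 (beyond the scatter) being beyond the scatter.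

Compound 4 `COC(=O)CCc1c(C)[nH]c(=O)c2c(N)nn(C)c12` differs from compound 2 by 2-(methoxycarbonyl)ethyl in place of hydrogen on an aromatic carbon. Among the measured compounds shown here, no measured step changes that position. For the measured compounds named here, the one step at an aromatic carbon, a number 3 percentage points lower from compound 2 to compound 3 (within the scatter), stayed within the scatter, so a step of no clear direction is expected: a number 1 percentage points lower from compound 2 to compound 4 (within the scatter). Compound 4 is therefore estimated at 10%, with a range from -6% to 26%.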

Compound 4, a percentage reported as inhibition, at one concentration (the size of the read-out at that concentration, not a potency): 5%
The estimate for compound 4 lay 5 percentage points above the measured number, and the stated range covers the measured number.
By their numbers in this assay, from the lowest: compounds 1, 4, 3 and 2 (each within the scatter of the next, the first and the last beyond it).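

In this assay, among the compounds shown here, this aromatic carbon, ortho to a methyl group, carries 2-(methoxycarbonyl)ethyl with a number 6 percentage points lower from compound 2 to compound 4 (within the scatter) and so gives the first reading at this position: a chain of this size brings no change that can be told from the scatter. No evidence at hand bears on this result.

From the compounds shown here alone, whether a carboxylic acid or an amine in place of the methyl ester, or a longer chain, would shift the number at this position stays open. Also open, going by these compounds, is whether the same chain would read alike on compound 3.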